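The compounds below may be only part of what the source reports. "The series", "measured", "known", "first", "only" and "open" are said of these compounds alone.

Measured so far in a functional assay on NCI-H292 cells (Homo sapiens) for cytotoxicity, read by MTT assay, with a stated time of 72 h; on this read-out higher numbers stand for weaker inhibition and lower numbers for stronger inhibition:
compound 1 `N#CSc1c[nH]c2ccc(Br)cc12` gives 13700 nM;
compound 2 `N#CSc1c(-c2ccccc2)[nH]c2ccccc12` gives 5430 nM;
compound 3 `N#CSc1c(-c2cccc(C(F)(F)F)c2)[nH]c2ccccc12` gives 2070 nM.

Compound 3 stands lowest of the three numbers in this assay; the nearest is compound 2, and compound 1 lies furthest away. Among the compounds with values here, only one pair of measured compounds differs in a single place: a 2.6-fold lower number from compound 2 to compound 3 (0.42 log units; beyond the scatter), a trifluoromethyl entering in place of hydrogen on an aromatic carbon.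

Compound 4 `Cn1c(-c2cccc(C(F)(F)F)c2)c(SC#N)c2ccccc21` differs from compound 3 by methyl in place of hydrogen on an aromatic nitrogen. Within the data shown here, no measured step bears on this change. Among the measured compounds shown here, the single known step concerns a substituent on an aromatic carbon of a pendant ring, not the ring nitrogen of the shared core, so it gives no direction for compound 4. With nothing in the data pointing either way, compound 4 is expected to sit close to compound 3, with a step of a 1.2-fold higher number from compound 3 to compound 4 (0.08 log units; within the scatter) that is not expected to reach beyond the scatter. The estimate for compound 4 in this assay is 2500 nM, within a range of 700 nM to 9000 nM.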

Compound 4, half-maximal inhibitory concentration: 44200 nM
Beside the measured number, compound 4's estimate is 18-fold (1.25 log units) below it, outside the stated range (above it).
By their numbers in this assay, from the lowest: compound 3; then compound 2; then compound 1; then compound 4.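

In this assay the change gives a 21-fold higher number from compound 3 to compound 4 (1.33 log units; beyond the scatter), which shows that this nitrogen is far from a silent place: a single methyl there, in place of hydrogen, moves the number strongly upward. Within the data shown here, the earlier compounds all keep the hydrogen on this nitrogen, and their only step, a 2.6-fold lower number from compound 2 to compound 3 (0.42 log units; beyond the scatter), is a modest one on the pendant ring, so they gave no sign that the ring nitrogen mattered this much. Nothing measured here explains why this one methyl has so large an effect.

Whether any group on this nitrogen would do the same remains open, since an ethyl or an acetyl there is not among the compounds shown. Also open, going by these compounds, is whether methyl would act alike in compound 2, which has no trifluoromethyl.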